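Swapping methoxy for chloro on a sulfonyl quinoline

The source may report more compounds than this note shows. Statements on the series, on what has been measured and on what is new or still open speak of the compounds shown alone.

Measured compounds:
compound 1 `COc1ccc(S(=O)(=O)c2cnc3cc(F)ccc3c2-c2cccc(Cl)c2)cc1Cl` gives 1.19 mL/min in an ADME assay on microsomes from liver (Homo sapiens) for metabolic stability, tested at 2.5 uM; on this read-out higher numbers stand for fast clearance and lower numbers for slow clearance;
compound 2 `COc1cccc(-c2c(S(=O)(=O)c3ccc(C)c(C)c3)cnc3cc(F)ccc23)c1` gives 8.78 mL/min in this assay.

Within the data shown here, of the two compounds measured so far, compound 2 stands at the higher number, and the gap to compound 1 lies beyond the scatter. Compound 1 and compound 2 differ from each other in two places, so the two values alone do not show which change carries the gap.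

Compound 3 `Cc1ccc(S(=O)(=O)c2cnc3cc(F)ccc3c2-c2cccc(Cl)c2)cc1C` is not yet measured. It differs from compound 2 by chloro in place of methoxy on an aromatic carbon. Among the measured compounds shown here, with no single-change step between measured compounds available, the expectation rests on compound 1 and its value of 1.19 mL/min: compound 3 now shares the 3-chlorophenyl of compound 1, so a step downward from compound 2 to compound 3 is expected, a 2.2-fold lower number from compound 2 to compound 3 (0.34 log units; beyond the scatter), of a size beyond the scatter but short of the full gap. For compound 3 the estimate is 4 mL/min, with a range from 1.5 mL/min to 10 mL/min.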

Compound 3, intrinsic clearance in a liver preparation (reported as CLH), per the amount of preparation that the assay uses: 4.01 mL/min
The estimate for compound 3 lay 1.0-fold (0.00 log units) below the measured number; measured number inside the range.
By their numbers in this assay, from the lowest: compound 1; then compound 3; then compound 2.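

In this assay, the change from 3-methoxyphenyl to 3-chlorophenyl, taken alone, gives a 2.2-fold lower number from compound 2 to compound 3 (0.34 log units; beyond the scatter), so this place on its own moves the number beyond the scatter. The other single change, 3,4-dimethylphenyl in place of 3-chloro-4-methoxyphenyl on the sulfonyl sulfur, gives a 3.4-fold higher number from compound 1 to compound 3 (0.53 log units; beyond the scatter), also beyond the scatter, so the sulfonyl side moves the number as well. Nothing at hand gives a reason for either step.

At this place the compounds shown hold only methoxy and chloro, so how a fluoro, a nitrile or an amine would read there stays open. Going by these compounds, whether chloro in place of methoxy gives a similar step alongside any sulfonyl group other than 3,4-dimethylphenyl also stays open.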